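This account rests on a few compounds, and the source may have more. Where it says the series, first, only, none or still open, it means among the compounds named here.

Three compounds of this study were tested in a functional assay on HepG2 cells (Homo sapiens) for antiproliferative activity, with a stated time of 72 h (a higher number here means that more compound is needed for the effect, a lower number that less compound is needed), and none of them gave a number. Compound 1, `COc1ccc(-c2cc(=O)c3c(OC)cc(OC)cc3n2S(=O)(=O)c2ccc(OC)cc2)cc1`, gives only a limit of the assay in this assay, > 82700 nM. Compound 2, `COc1cc(OC)c2c(=O)cc(C(=O)Nc3ccc(-n4cccc4)cc3)[nH]c2c1`, likewise reaches only a limit in this assay, > 77000 nM. Compound 3, `COC(=O)c1cc(=O)c2cc(NC(=O)Nc3ccc(Cl)c(C(F)(F)F)c3)ccc2[nH]1`, stands at a limit as well, > 6350 nM in this assay. So compound 3 has no numerical standing among the three: all that is known is the limit of > 6350 nM in this assay, at which 1 of the 3 values shown sits, alongside the limit of > 77000 nM in this assay, at which 1 of the 3 values shown sits, and the limit of > 82700 nM in this assay, at which 1 of the 3 values shown sits, for the other two.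

Compound 4, `COC(=O)c1cc(=O)c2cc(NC(=O)Nc3ccc(Cl)c(Cl)c3)ccc2[nH]1`, has not yet been measured in this assay. It differs from compound 3 in one place only: chloro in place of trifluoromethyl on an aromatic carbon. Going by the values given here, no measured step between two compounds of this set exists, so the size of the expected change rests on the single limit of compound 3 alone. The step from compound 3 to compound 4 is expected to be a step that the limit leaves unreadable from compound 3 to compound 4, which is no step beyond the usual scatter in either direction. Compound 4 is therefore expected to give about 10000 nM in this assay, within a range from 3000 nM to 40000 nM, and most likely again only a limit rather than a number.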

Compound 4, half-maximal effective concentration: > 6350 nM
Compound 4: a limit, no number (the forecaster's own chance of this, stated with the estimate: 70%); the middle value does not contradict the limit.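

Compound 4 gives only a limit in this assay, > 6350 nM. Going by these compounds alone, with compound 3 also at a limit, no step between compound 3 and compound 4 can be read. The compounds shown leave open how much of either compound is needed for the effect, and whether chloro in place of trifluoromethyl on an aromatic carbon changes it at all.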